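Swapping chloro for bromo on a benzimidazole-imidazopyrazine

This account rests on a few compounds, and the source may have more. Where it says the series, first, only, none or still open, it means among the compounds named here.

Measured so far in a functional assay on NCI-H522 cells (Homo sapiens) for inhibition, read by sulforhodamine B assay, with a stated time of 48 h, tested at 10 uM; a lower number here means less inhibition, a higher number more inhibition at the concentration tested (going by the name of the read-out):
compound 1, `c1cn2cc(-c3ccsc3)nc(-c3ccc4ncn(C5CCCCC5)c4c3)c2n1`, 10.3%
compound 2, `Clc1ccc(-c2cn3ccnc3c(-c3ccc4ncn(C5CCCCC5)c4c3)n2)cc1`, 19.8%

Among the measured compounds shown here, compound 2 gives the higher of the two numbers, but the only step to it, a number 9.5 percentage points higher from compound 1 to compound 2 (within the scatter), lies within the scatter, so the two compounds cannot be told apart on these data. Compound 3, `Brc1ccc(-c2cn3ccnc3c(-c3ccc4ncn(C5CCCCC5)c4c3)n2)cc1`, differs from compound 2 in one place: bromo in place of chloro on an aromatic carbon. For the measured compounds named here, no measured step exchanges one halogen for another; the single step available concerns a different group and is itself within the scatter. There is therefore nothing in this assay pointing to a change beyond the scatter, and the expected step, a number 0.2 percentage points higher from compound 2 to compound 3 (within the scatter), is estimated to be small. Compound 3 is accordingly estimated at 20% in this assay, with a range from 5% to 36%.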

Compound 3, a percentage reported as inhibition, at one concentration (the size of the read-out at that concentration, not a potency): 35.5%
Compound 3: middle estimate off by 15.5 percentage points, on the low side; the measured number falls inside the stated range.
By their numbers in this assay, from the lowest: compounds 1 and 2 (each within the scatter of the next); then compound 3.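

Among the compounds shown here, at the carbon para to a large group, exchanging one halogen for another is enough to shift the result in this assay: bromo in place of chloro gives a number 15.7 percentage points higher from compound 2 to compound 3 (beyond the scatter), the first single change here to clear the scatter. Replacing the thiophen-3-yl of compound 1 with 4-bromophenyl gives a number 25.2 percentage points higher from compound 1 to compound 3 (beyond the scatter), so at this site the outcome depends on which halogen the phenyl ring carries, not only on the ring being there. No measurement at hand gives a reason for the difference between bromo and chloro.

The compounds shown leave open whether iodo would extend this rise, or whether a non-halogen group at the same carbon, such as an amine or a methoxy, would match bromo. Going by these compounds, whether the cyclohexyl group on the shared core contributes to the result also remains open, as it is the same in all three compounds.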